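This account rests on a few compounds, and the source may have more. Where it says the series, first, only, none or still open, it means among the compounds named here.

Measured so far:
compound 1, `O=C(/C=C/c1cccc(OCc2ccccc2)c1)c1ccccc1`: in a functional assay on ZR-75-1 cells (Homo sapiens) for cytotoxicity, read by MTT assay, with a stated time of 68 h (on this read-out higher numbers stand for weaker inhibition and lower numbers for stronger inhibition), compound 1 gives 8500 nM
compound 2, `O=C(/C=C/c1cccc(OCc2ccccc2)c1)c1ccc(Cl)cc1`: in this assay compound 2 gives 20000 nM

Among the measured compounds shown here, compound 2 gives the highest of the two numbers; the only measured step, a 2.4-fold higher number from compound 1 to compound 2 (0.37 log units; beyond the scatter), separates it from compound 1, and that step is chloro in place of hydrogen on an aromatic carbon. Compound 3, `O=C(/C=C/c1cccc(OCc2ccccc2)c1)c1ccc(Cl)c(Cl)c1Cl`, differs from compound 2 in one place: 2,3,4-trichlorophenyl in place of 4-chlorophenyl on a carbonyl carbon. For the measured compounds named here, the one step that bears on this change is a 2.4-fold higher number from compound 1 to compound 2 (0.37 log units; beyond the scatter), a modest rise in the number. Here the entering group carries more chlorine than the leaving one, and no measured step shows what that does; the single chlorine step is the only guide. The expectation is therefore a further modest rise in the number, of about a 1.5-fold higher number from compound 2 to compound 3 (0.18 log units; within the scatter), possibly beyond the scatter. Compound 3 is estimated at 30000 nM, with a range from 10000 nM to 90000 nM.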

Compound 3, half-maximal inhibitory concentration: 6200 nM
Compound 3: the middle estimate sits 4.8-fold (0.68 log units) above what was measured, and the stated range ends above it.
By their numbers in this assay, from the lowest: compounds 3 and 1 (each within the scatter of the next); then compound 2.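

Working notes on the aryl group on the carbonyl carbon: in this assay, the number does not follow the chlorine count. 2,3,4-Trichlorophenyl in place of 4-chlorophenyl runs the opposite way (a 3.2-fold lower number from compound 2 to compound 3 (0.51 log units; beyond the scatter)) to the earlier step of chloro in place of hydrogen (a 2.4-fold higher number from compound 1 to compound 2 (0.37 log units; beyond the scatter)), so the rise seen with 4-chlorophenyl does not extend to the more heavily chlorinated group. Measured against phenyl, 2,3,4-trichlorophenyl stays within the scatter (a 1.4-fold lower number from compound 1 to compound 3 (0.14 log units; within the scatter)), and no data shown here explain the change of direction.

Still open, from the compounds shown here alone, is whether this turn belongs to one particular chlorine on the ring or needs all three together. Also open, going by these compounds, is whether a fluoro, a methoxy or an amine on the same phenyl ring would track either chlorinated group.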